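The source may report more compounds than this note shows. Statements on the series, on what has been measured and on what is new or still open speak of the compounds shown alone.

Compound 1, `N#Cc1ccccc1COc1c(-c2ccccc2)oc2cc(O)cc(O)c2c1=O`, gives in an ADME assay on Huh-5-2 cells (Homo sapiens) for cytotoxicity, read by WST assay, with a stated time of 3 days (on this read-out lower numbers stand for higher toxicity in this test and higher numbers for lower toxicity in this test), a value that is a limit of the test, > 100000 nM. Compound 2, `COc1ccccc1COc1c(-c2ccccc2)oc2cc(O)cc(O)c2c1=O`, gives in this assay 53000 nM. Compound 3, `O=c1c(OCc2ccc(Br)cc2)c(-c2ccccc2)oc2cc(O)cc(O)c12`, gives in this assay 2000 nM.

Compound 3 holds the lowest of the two numbers; its nearest neighbour is compound 2, and the step of a 27-fold lower number from compound 2 to compound 3 (1.42 log units; beyond the scatter) lies beyond the scatter. Compound 4, `COc1ccc(COc2c(-c3ccccc3)oc3cc(O)cc(O)c3c2=O)cc1`, differs from compound 3 by methoxy in place of bromo on an aromatic carbon. Among the compounds with values here, no measured step swaps exactly these two groups on the same carbon. The steps that come nearest are an at least 50-fold lower number from compound 1 to compound 3 (1.69 log units; beyond the scatter) and a 27-fold lower number from compound 2 to compound 3 (1.42 log units; beyond the scatter), both large, showing that the 4-bromobenzyl group goes with a far lower number than the 2-cyanobenzyl and 2-methoxybenzyl groups, while the step of an at least 1.8-fold lower number from compound 1 to compound 2 (0.27 log units; that floor lies within the scatter) is small. Within the data shown here, since the bromo leaves in compound 4, the number is expected to move back up, by the step of a 10-fold higher number from compound 3 to compound 4 (1.00 log units; beyond the scatter), though a methoxy para to the large group has no direct precedent among the measured compounds. Compound 4 is estimated at 20000 nM, with a range from 5000 nM to 80000 nM.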

Compound 4, half-maximal cytotoxic concentration: 57000 nM
For compound 4 the middle estimate is 2.9-fold (0.45 log units) below the measured one; the range from low to high includes it.
By their numbers in this assay, from the lowest: compound 3; then compounds 2 and 4 (each within the scatter of the next). At a limit, above all of these: compound 1.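

In this assay, the exchange on this aromatic carbon, para to a large group, is itself large: a 29-fold higher number from compound 3 to compound 4 (1.45 log units; beyond the scatter), so the low number of compound 3 goes with bromo and not with every group on that carbon. The two methoxy compounds cannot be told apart, a 1.1-fold higher number from compound 2 to compound 4 (0.03 log units; within the scatter), which means that among these two the place of the methoxy on the ring makes no difference that can be read. Against the limit of the test, an at least 1.7-fold lower number from compound 1 to compound 4 (0.24 log units; that floor lies within the scatter) gives only a floor: the limit of > 100000 nM in this assay, at which 1 of the 4 values shown sits.

Only compound 3 carries bromo, so the compounds shown do not tell whether chloro, fluoro or methyl on that carbon would go with a number like that of compound 3 or like that of compound 4. From the compounds shown here alone, how an amine or a hydroxyl there would read also stays open.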